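Pyrazin-2-yl to 6-cyanopyridin-2-yl on the shared core

The source may report more compounds than this note shows. Statements on the series, on what has been measured and on what is new or still open speak of the compounds shown alone.

Compound 3 `Nc1nc(-c2cnccn2)nc2sc(Cc3ccccc3)cc12` gives 91 nM in a functional assay on CHO-K1 cells for antagonist activity at adenosine receptor A1 (Homo sapiens), read by a beta-galactosidase reporter and cAMP accumulation, with stated times of 15 min and 6 h (a lower number here means a stronger inhibitor, a higher number a weaker inhibitor), the lowest of the three numbers measured. Compound 2 `COc1cccc(-c2nc(N)c3cc(Cc4ccccc4)sc3n2)c1` gives 266 nM and compound 1 `Nc1nc(C2CCCO2)nc2sc(Cc3ccccc3)cc12` gives 2950 nM. The steps of an 11-fold lower number from compound 1 to compound 2 (1.04 log units; beyond the scatter), a 32-fold lower number from compound 1 to compound 3 (1.51 log units; beyond the scatter) and a 2.9-fold lower number from compound 2 to compound 3 (0.47 log units; beyond the scatter) show that the group on this aromatic carbon matters, and that swapping oxolan-2-yl for either aromatic group brought the larger gains. Compound 4 `N#Cc1cccc(-c2nc(N)c3cc(Cc4ccccc4)sc3n2)n1` carries 6-cyanopyridin-2-yl in place of pyrazin-2-yl on an aromatic carbon. Both outgoing and incoming groups are six-membered aromatic rings, so the change resembles the modest step between compound 2 and compound 3 rather than the large ones from compound 1. A step no larger than that is expected, with no firm direction. The expected step is a 1.1-fold higher number from compound 3 to compound 4 (0.04 log units; within the scatter). Compound 4 is estimated at 100 nM, within 30 nM to 350 nM.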

Compound 4, inhibition constant: > 1000 nM
Compound 4 ended at the assay's limit; the forecaster's own chance of this, stated with the estimate: 2%; at least 10-fold (1.00 log units) between middle value and limit.
By their numbers in this assay, from the lowest: compound 3; then compound 2; then compound 1.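

The position separates six-membered aromatic rings sharply: 6-cyanopyridin-2-yl gives an at least 10-fold higher number from compound 3 to compound 4 (1.04 log units; beyond the scatter), and against 3-methoxyphenyl it gives an at least 3.7-fold higher number from compound 2 to compound 4 (0.57 log units; beyond the scatter). Compound 4 gives > 1000 nM, which is a limit of the assay and not a number. The step from compound 1 to compound 4 cannot be read, and an aromatic ring at this position no longer suffices for a low number.

Open, from the compounds shown here alone, is whether the rise follows the nitrile or the pyridine ring. Unsubstituted pyridin-2-yl and 3-cyanophenyl would separate the two.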